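The source may hold more compounds than are shown below. What is called first, only, known or untested is meant among the compounds shown, and "the series" means these compounds.

Measured compounds:
Compound 1 `O=C1O/C(=C\Cn2cc(-c3ccc(Br)cc3)nn2)C(OCc2ccccc2)=C1OCc1ccccc1`: in a functional assay on HCT-116 cells (Homo sapiens) for antiproliferative activity, read by MTT assay, with a stated time of 72 h (a higher number here means a weaker inhibitor, a lower number a stronger inhibitor), compound 1 gives > 100000 nM, a limit of the assay.
Compound 2 `COc1ccccc1-c1cn(C[C@H](O)[C@H]2OC(=O)C(OCc3ccccc3)=C2OCc2ccccc2)nn1`: in this assay compound 2 gives > 100000 nM, a limit of the assay.
Compound 3 `COc1ccccc1-c1cn(C/C=C2\OC(=O)C(OCc3ccccc3)=C2OCc2ccccc2)nn1`: in this assay compound 3 gives > 100000 nM, a limit of the assay.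

Compound 2 thus stands at a limit in this assay and has no number of its own; the same holds for compound 1 and compound 3, as the limit of > 100000 nM in this assay, at which 3 of the 3 values shown sit, records. Going by the values given here, the only measured step, a step that the two limits leave unreadable from compound 1 to compound 3, is unreadable for that reason. Compound 4 `O=C1O[C@H]([C@@H](O)Cn2ccnn2)C(OCc2ccccc2)=C1OCc1ccccc1` differs from compound 2 by hydrogen in place of 2-methoxyphenyl on an aromatic carbon. Among the compounds with values here, no measured step bears on this change, and no direction can be read from the limits. Compound 4 is expected to remain at the limit, a step that the limit leaves unreadable from compound 2 to compound 4. Compound 4 is estimated at 150000 nM, between 50000 nM and 500000 nM.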

Compound 4, half-maximal inhibitory concentration: > 100000 nM
Compound 4 was reported as a limit; the forecaster's own chance of this, stated with the estimate: 85%; the middle value does not contradict the limit.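

Compound 4, like compound 2, stands at a limit, so no step between them can be read, and one limit holds throughout: the limit of > 100000 nM in this assay, at which 4 of the 4 values shown sit.

The compounds shown leave open whether any change to the shared core would give a number of its own in this assay.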